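The source may report more compounds than this note shows. Statements on the series, on what has been measured and on what is new or still open speak of the compounds shown alone.

Measured compounds in a functional assay on L1210 cells (Mus musculus) for antiproliferative activity, with a stated time of 48 h; a lower number here means a stronger inhibitor, a higher number a weaker inhibitor:

Compound 1 `C=C(Br)C(=O)Nc1ccc(/C=C/C(=O)c2ccc(Br)cc2)cc1`, compound 1 gives 620 nM.
Compound 2 `C=C(Br)C(=O)Nc1ccc(C(=O)/C=C/c2ccccc2)cc1`, compound 2 gives 880 nM.
Compound 3 `Nc1ccc(/C=C/C(=O)c2ccc(Br)cc2)cc1`, compound 3 gives 90000 nM.

Compound 1 and compound 3 differ in one place:

hydrogen in place of (1-bromoethenyl)carbonyl on a nitrogen on an aromatic ring

This change gives a 150-fold higher number from compound 1 to compound 3 (2.16 log units; beyond the scatter), a large step beyond the scatter. Compound 1 and compound 2 differ in their cores; the difference between the two cores is not broken down here. Their values in this assay lie within the scatter of each other.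

Compound 4 `Nc1ccc(C(=O)/C=C/c2ccccc2)cc1` is not yet measured. It stands to compound 2 as compound 3 stands to compound 1:

hydrogen in place of (1-bromoethenyl)carbonyl on a nitrogen on an aromatic ring

The place is the same word for word in both pairs, so this is the same change, seen once in a measured pair and now a second time. The expectation rests on that single measured pair: because a 150-fold higher number from compound 1 to compound 3 (2.16 log units; beyond the scatter) was large, a step of similar size is expected from compound 2 to compound 4, namely a 140-fold higher number from compound 2 to compound 4 (2.13 log units; beyond the scatter). Within the data shown here, with only one prior example the range is kept wide. Compound 4 is thus estimated at 120000 nM, between 30000 nM and 400000 nM.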

Compound 4, half-maximal inhibitory concentration: 14000 nM
For compound 4 the middle estimate is 8.6-fold (0.93 log units) above the measured one; measured number below the stated range.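

In this assay, replacing (1-bromoethenyl)carbonyl with hydrogen on the nitrogen again gives a large step in the same direction, with a 16-fold higher number from compound 2 to compound 4 (1.20 log units; beyond the scatter), so the direction of the change carries from the core of compound 1 to the core of compound 2. The size of the step does not carry over unchanged, and the two measured steps differ: the same change on two cores in this assay, a 150-fold higher number (2.16 log units; beyond the scatter) from compound 1 to compound 3 and a 16-fold higher number (1.20 log units; beyond the scatter) from compound 2 to compound 4, 9.1-fold (0.96 log units) apart, beyond the scatter of two such steps. Two pairs show that the direction held on these two cores, but they do not give a size that can be relied on for a further core, and they do not show which difference between the cores goes with the gap between the steps.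

The compounds shown have only (1-bromoethenyl)carbonyl or hydrogen on this nitrogen, so it remains open how an acetyl or a chloroacetyl group in the same place would compare in this series. From the compounds shown here alone, it also remains open whether the step on a third core would lie nearer the larger or the smaller of the two steps.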